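Trifluoromethyl for chloro on the urea aryl of compound 2

The source may report more compounds than this note shows. Statements on the series, on what has been measured and on what is new or still open speak of the compounds shown alone.

Measured so far:
compound 1 `COc1cc(-c2nn(-c3cccc(NC(=O)Nc4cc(C(F)(F)F)cc(C(F)(F)F)c4)c3)cc2-c2ccncc2)ccc1Cl` — 2430 nM
compound 2 `COc1cc(-c2nn(-c3cccc(NC(=O)Nc4ccc(Cl)c(Cl)c4)c3)cc2-c2ccncc2)ccc1Cl` — 20300 nM
compound 3 `O=C(Nc1cccc(-n2cc(-c3ccncc3)c(-c3ccc(Cl)c(O)c3)n2)c1)Nc1ccc(Cl)c(Cl)c1` — 10900 nM

In a functional assay on SF-268 cells (Homo sapiens) for inhibition, read by sulforhodamine B assay, with a stated time of 48 h (on this read-out higher numbers stand for weaker inhibition of growth and lower numbers for stronger inhibition of growth), compound 2 gives the highest of the three numbers. Compound 3 lies nearest, with a 1.9-fold lower number from compound 2 to compound 3 (0.27 log units; within the scatter), a change of hydrogen in place of methyl on an oxygen. Among the compounds with values here, compound 1 lies furthest, and its value against that of compound 2 shows a gap beyond the scatter, but the two differ in more than one place, so no single step is known for it.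

Compound 4 `COc1cc(-c2nn(-c3cccc(NC(=O)Nc4ccc(Cl)c(C(F)(F)F)c4)c3)cc2-c2ccncc2)ccc1Cl` is the next case: trifluoromethyl in place of chloro on an aromatic carbon. Within the data shown here, no measured step covers this exact change. Among the measured compounds shown here, the only guide is that compound 1, carrying two trifluoromethyl groups, shows a lower number than compound 2 with two chloro groups; compound 4 sits between those two, so a lower number than compound 2 is expected, of moderate size, a 2.9-fold lower number from compound 2 to compound 4 (0.46 log units; beyond the scatter). For compound 4 the expected value is 7000 nM, with a range from 2500 nM to 18000 nM.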

Compound 4, concentration for total growth inhibition: 9140 nM
Estimate against measurement, compound 4: 1.3-fold (0.12 log units) below; the measured number falls inside the stated range.
By their numbers in this assay, from the lowest: compound 1; then compounds 4, 3 and 2 (each within the scatter of the next, the first and the last beyond it).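

In this assay, the change from 3,4-dichlorophenyl to 4-chloro-3-(trifluoromethyl)phenyl gives a 2.2-fold lower number from compound 2 to compound 4 (0.35 log units; beyond the scatter). Within the data shown here, this is the first single-place reading of trifluoromethyl in place of chloro on this aromatic carbon, and it shows that the larger group is accepted there, with a modest shift towards stronger inhibition of growth. No measurement at hand bears on the origin of this step.

Open, from the compounds shown here alone, is how a nitrile or an amine on this same carbon would read. Also open, going by these compounds, is whether the step holds with the free hydroxyl of compound 3.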